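The compounds below may be only part of what the source reports. "The series", "measured", "known", "first", "only" and "open" are said of these compounds alone.

Measured compounds:
Compound 1, `CCCCCCCOc1c(-c2cc(OC)c(OC)c(OC)c2)oc2ccccc2c1=O`, in a functional assay on LNCaP cells (Homo sapiens) for antiproliferative activity, read by WST assay, with a stated time of 3 days (a lower number here means a stronger inhibitor, a higher number a weaker inhibitor), gives only a limit of the assay, > 50000 nM.
Compound 2, `COc1cc(-c2oc3ccccc3c(=O)c2OC(C)C)cc(OC)c1OC`, gives 8800 nM in this assay.
Compound 3, `CCC(C)Oc1c(-c2cc(OC)c(OC)c(OC)c2)oc2ccccc2c1=O`, gives 9300 nM in this assay.

Among the two numbers shown, compound 2 gives the lowest, and compound 3 sits beside it: a 1.1-fold higher number from compound 2 to compound 3 (0.02 log units; within the scatter), so the two cannot be told apart. The heptyl compound 1 stands apart from both, since it reaches only the limit described in the limit of > 50000 nM in this assay, at which 1 of the 3 values shown sits, and the steps from it are an at least 5.6-fold lower number from compound 1 to compound 2 (0.75 log units; beyond the scatter) and an at least 5.3-fold lower number from compound 1 to compound 3 (0.73 log units; beyond the scatter).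

The unmeasured compound 4, `CCCN(CCC)CCCOc1c(-c2cc(OC)c(OC)c(OC)c2)oc2ccccc2c1=O`, departs from compound 2 by 3-(dipropylamino)propyl in place of isopropyl on an oxygen on an aromatic ring. Among the compounds with values here, no measured step changes the group on that oxygen in quite this way; the nearest guide is the heptyl compound 1, where a long chain on the same oxygen went along with a number at the limit, whereas the branched isopropyl and sec-butyl groups of compounds 2 and 3 gave measurable values. The new group is again a long chain, so a higher number than compound 2 is expected, and the step is estimated as a 3.4-fold higher number from compound 2 to compound 4 (0.53 log units; beyond the scatter), with a real chance that only a limit is reported. Compound 4 is therefore expected to give about 30000 nM in this assay, within a range from 8000 nM to 100000 nM.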

Compound 4, half-maximal inhibitory concentration: 17900 nM
Estimate against measurement, compound 4: 1.7-fold (0.22 log units) above, and the stated range covers the measured number.
By their numbers in this assay, from the lowest: compounds 2, 3 and 4 (each within the scatter of the next, the first and the last beyond it). At a limit, above all of these: compound 1.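

On the oxygen on an aromatic ring, a long chain no longer goes with a limit: in this assay the 3-(dipropylamino)propyl group gives a measurable number, and with dipropylamino in place of butyl the step reads an at least 2.7-fold lower number from compound 1 to compound 4 (0.44 log units; beyond the scatter). Set against the branched groups, the new chain changes little: the step from isopropyl is modest, a 2.0-fold higher number from compound 2 to compound 4 (0.31 log units; beyond the scatter), and the step from sec-butyl, a 1.9-fold higher number from compound 3 to compound 4 (0.28 log units; within the scatter), cannot be told from the scatter. Chain length alone therefore does not set the outcome at this position, and among these compounds only the heptyl compound 1 remains at a limit of the assay: the limit of > 50000 nM in this assay, at which 1 of the 4 values shown sits.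

On these data alone, whether the nitrogen of the dipropylamino group is what separates compound 4 from compound 1 stays open, as this rests on a single pair, and a shorter amine such as dimethylamino on the same propyl chain, or a carboxylic acid there, would bear on it. Also open, as far as these compounds go, is whether any group on this oxygen, such as a small methyl or a benzyl, can take the number well past that of compound 2, 8800 nM.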